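Propargyl on the indole nitrogen of the carbamate series

The source may hold more compounds than are shown below. What is called first, only, known or untested is meant among the compounds shown, and "the series" means these compounds.

Measured so far:
compound 1 `CCN(CC)C(=O)Oc1ccc2[nH]ccc2c1`: > 100000 nM
compound 2 `C#CCn1ccc2cc(NC(=O)N(CC)CC)ccc21`: 28800 nM
compound 3 `C#CCn1ccc2ccc(NC(=O)N(CC)CC)cc21`: 2620 nM

For the measured compounds named here, in an assay on isolated protein for inhibition of Amine oxidase [flavin-containing] B (Homo sapiens), read by fluorescence, with stated times of 10 min, 10 s and 20 min (a lower number here means a stronger inhibitor, a higher number a weaker inhibitor), compound 1 reaches only the limit of the assay; its figure of > 100000 nM is a limit, not a number, and it is the one value of the three that sits there (the limit of > 100000 nM in this assay, at which 1 of the 3 values shown sits). Compound 2 and compound 3 give numbers, with compound 3 the stronger of the two.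

Compound 4 `C#CCn1ccc2cc(OC(=O)N(CC)CC)ccc21` differs from compound 1 by propargyl in place of hydrogen on an aromatic nitrogen. Going by the values given here, no measured pair shows this step. Compound 4 is expected to be stronger than compound 1, the estimated step of an at least 10-fold lower number from compound 1 to compound 4 (1.00 log units; beyond the scatter), because compound 2 gives 28800 nM with a number rather than a limit. For compound 4 the estimate is 10000 nM, between 1500 nM and 60000 nM.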

Compound 4, half-maximal inhibitory concentration: 16500 nM
Compound 4: middle estimate off by 1.7-fold (0.22 log units), on the low side; measured number inside the range.
By their numbers in this assay, from the lowest: compound 3; then compounds 4 and 2 (each within the scatter of the next). At a limit, above all of these: compound 1.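

In this assay, propargyl in place of hydrogen on the aromatic nitrogen gives an at least 6.0-fold lower number from compound 1 to compound 4 (0.78 log units; beyond the scatter), the only direct reading of this change among the compounds shown. The step is a lower bound, since compound 1 stands at a limit and not at a number: the limit of > 100000 nM in this assay, at which 1 of the 4 values shown sits.

The compounds shown leave open whether the triple bond is needed for this step, which a propyl or methyl group on the same nitrogen would test. Also open, going by these compounds, is whether the step holds when the diethylamino part of the carbamate gives way to a pyrrolidine.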